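The compounds below may be only part of what the source reports. "The series", "measured", "known", "first", "only" and "open" are said of these compounds alone.

In a functional assay on MCF7 cells (Homo sapiens) for inhibition, read by CCK-8 assay, with a stated time of 48 h (on this read-out lower numbers stand for stronger inhibition of growth and higher numbers for weaker inhibition of growth), three compounds have been measured: compound 1 `CN1CCN(c2ccc(Nc3ncc(Cl)c(Nc4ccccc4)n3)nc2)CC1` gives 51800 nM, compound 2 `CN1CCN(c2ccc(Nc3ncc(Cl)c(NCc4ccc(C(F)(F)F)cc4)n3)nc2)CC1` gives 28400 nM and compound 3 `COc1cccc(CNc2nc(Nc3ccc(N4CCN(C)CC4)cn3)ncc2Cl)c1` gives 19500 nM. The nearest gap to compound 3 is small, at a 1.5-fold lower number from compound 2 to compound 3 (0.16 log units; within the scatter). The only gap that clears the scatter is a 2.7-fold lower number from compound 1 to compound 3 (0.42 log units; beyond the scatter), whereas the remaining gap is a 1.8-fold lower number from compound 1 to compound 2 (0.26 log units; within the scatter).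

Compound 4 `CCc1ccc(Nc2nc(Nc3ccc(N4CCN(C)CC4)cn3)ncc2Cl)cc1` differs from compound 3 by 4-ethylphenyl in place of 3-methoxybenzyl on a nitrogen on an aromatic ring. This puts an aromatic ring directly on that nitrogen again, as in compound 1, so a 2.7-fold lower number from compound 1 to compound 3 (0.42 log units; beyond the scatter) bears on the change when read in reverse. Going by the values given here, no measured compound shows what the ethyl group contributes on its own. A small move towards a higher number is therefore expected, probably within the scatter, and the estimated step is a 1.6-fold higher number from compound 3 to compound 4 (0.22 log units; within the scatter). For compound 4 the expected value is 32000 nM, with an estimated range from 13000 nM to 75000 nM.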

Compound 4, concentration for 50% growth inhibition: 8230 nM
Estimate against measurement, compound 4: 3.9-fold (0.59 log units) above, and the stated range ends above it.
By their numbers in this assay, from the lowest: compound 4; then compounds 3, 2 and 1 (each within the scatter of the next, the first and the last beyond it).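

In this assay the nitrogen on an aromatic ring no longer needs a benzyl group for the lower numbers: with an aromatic ring directly on that nitrogen, ethyl in place of hydrogen on an aromatic carbon gives a 6.3-fold lower number from compound 1 to compound 4 (0.80 log units; beyond the scatter). The 4-ethylphenyl group also goes past both benzyl groups, with a 2.4-fold lower number from compound 3 to compound 4 (0.37 log units; beyond the scatter) and a 3.5-fold lower number from compound 2 to compound 4 (0.54 log units; beyond the scatter), so among these four compounds the choice of ring substituent at this place counts for at least as much as the saturated carbon of a benzyl group. No measurement given here accounts for these steps.

The compounds shown leave open whether the ethyl group is special or whether a longer chain, as in 4-propylphenyl, would go further. They also leave open how an amine or a carboxylic acid in that place on the phenyl ring would read.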